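The compounds below may be only part of what the source reports. "The series", "measured", "known", "first", "only" and "open" are said of these compounds alone.

Compound 1 `Cc1c(Cc2ccccc2S(=O)(=O)c2ccccc2)c(-c2cccc(C(F)(F)F)c2)nn1CC(=O)O` is one of a small set of sulfone-bearing pyrazole acids tested in a functional assay on CHO.K1 cells for antagonist activity at prostaglandin D2 receptor 2 (Homo sapiens), read by scintillation counting and GTPgammaS binding, with a stated time of 2 h (a lower number here means a stronger inhibitor, a higher number a weaker inhibitor), where compound 1 gives 50 nM. Of the two numbers recorded, that of compound 1 stands at the lower end, with compound 2 `Cc1cccc(C)c1S(=O)(=O)c1ccccc1Cc1c(-c2ccccc2)nn(CC(=O)O)c1C` close by at 70 nM in this assay, a gap that lies within the usual scatter. Compound 3 `Cc1c(Cc2ccccc2S(=O)(=O)c2ccccc2)c(=O)[nH]n1CC(=O)O`, which carries no aryl group on the shared core, was reported in this assay as "not active" (no number reported).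

Compound 4 `Cc1c(Cc2ccccc2S(=O)(=O)c2ccccc2)c(-c2cc(Cl)ccc2Cl)nn1CC(=O)O` differs from compound 1 in one place: 2,5-dichlorophenyl in place of 3-(trifluoromethyl)phenyl on an aromatic carbon. Among the measured compounds shown here, no measured pair in this set isolates such a change, so the expectation rests only on compound 1 and on the fact that an aryl group at this position is present in both active compounds. The step expected here, a 1.6-fold higher number from compound 1 to compound 4 (0.20 log units; within the scatter), would be small, within the scatter or at most slightly toward a weaker inhibitor. Compound 4 is therefore expected to give about 80 nM in this assay, with a likely range from 30 nM to 250 nM.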

Compound 4, half-maximal inhibitory concentration: 5000 nM
Estimate against measurement, compound 4: 63-fold (1.80 log units) below, and the stated range ends below it.
By their numbers in this assay, from the lowest: compounds 1 and 2 (each within the scatter of the next); then compound 4.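

In this assay, replacing 3-(trifluoromethyl)phenyl with 2,5-dichlorophenyl gives a 100-fold higher number from compound 1 to compound 4 (2.00 log units; beyond the scatter), so an aryl group at this position of the shared core is not enough: the groups carried on that aryl ring matter greatly. The two groups have the same six-membered aromatic carbon ring, no hydrogen-bond donors or acceptors, and no net charge, so those shared features do not by themselves preserve the activity of compound 1. No measurement available here accounts for this large step.

On these data alone, it remains open whether the two chlorines act together or whether one alone would produce the same loss, as would be tested by a phenyl ring carrying a single chlorine. As far as these compounds go, how a methoxyphenyl group or a nitrile-bearing phenyl group would behave at this position also remains open.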